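This account rests on a few compounds, and the source may have more. Where it says the series, first, only, none or still open, it means among the compounds named here.

Working notes on the series. Three compounds share a carboxy-thiazolyl substituent on a fused bicyclic core and have been run in an assay on isolated protein for antagonist activity at prostaglandin E2 receptor EP1 subtype (Homo sapiens), read by reporter gene assay; a higher number here means a weaker inhibitor, a lower number a stronger inhibitor. Compound 1 `O=C(O)c1csc(-n2cc(-c3ccccc3)c3ccccc32)n1` gives 120 nM. Compound 2 `Nc1ccc2c(-c3ccccc3)nn(-c3nc(C(=O)O)cs3)c2c1` gives 19 nM. Compound 3 `O=C(O)c1csc(-n2nc(-c3ccc(F)cc3)c3ccccc32)n1` gives 4.5 nM, the lowest of the three numbers; its gaps to compound 2 and to compound 1 are both beyond the scatter, so compound 3 is the strongest inhibitor measured so far. Among the measured compounds shown here, no two measured compounds differ in one place only, so no single change has yet been tied to a step in this assay.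

Compound 4 `CC1CCN(c2nn(-c3nc(C(=O)O)cs3)c3ccccc23)CC1` is not yet measured. Relative to compound 3 it carries a saturated amine ring where compound 3 carries an aromatic ring: 4-methylpiperidin-1-yl in place of 4-fluorophenyl on an aromatic carbon. Nothing in the measured set speaks to an exchange of this kind. The step of an 8.9-fold higher number from compound 3 to compound 4 (0.95 log units; beyond the scatter) is expected to be a loss, beyond the scatter, of moderate size. Compound 4 is therefore estimated at 40 nM, with a range from 8 nM to 200 nM in this assay.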

Compound 4, half-maximal inhibitory concentration: 32 nM
The estimate for compound 4 lay 1.3-fold (0.10 log units) above the measured number; low and high end bracket the measured number.
By their numbers in this assay, from the lowest: compound 3; then compounds 2 and 4 (each within the scatter of the next); then compound 1.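

In this assay, among the compounds shown here, 4-methylpiperidin-1-yl in place of 4-fluorophenyl on this aromatic carbon, next to the ring nitrogen, gives a 7.1-fold higher number from compound 3 to compound 4 (0.85 log units; beyond the scatter), the first change that can be read at a single place. The position therefore accepts a non-aromatic ring carrying a ring nitrogen at a modest cost, and compound 4 still gives 32 nM rather than losing activity altogether. No measurement available here bears on what sets the size of this step.

Going by these compounds, it remains open whether the step follows from the loss of the aromatic ring, the entry of the ring nitrogen or the methyl group on the piperidine. A 4-methylcyclohexyl group, an unsubstituted piperidin-1-yl or a morpholin-4-yl group on the same carbon would begin to separate these.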